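Methoxy for Bromo on the Carbonyl Aryl of Compound 2

A few compounds are considered here, and "the series" means these few. Any claim that something is new, unique, unknown or untested is made for them only; others in the source may bear on it.

Three compounds have been measured in a functional assay on A549 cells (Homo sapiens) for inhibition, read by MTT assay, with a stated time of 48 h, tested at 10 uM; a lower number here means less inhibition of growth, a higher number more inhibition of growth at the concentration tested:

compound 1 `O=C(/C=C/c1ccc(OCc2cn(Cc3cccc(Br)c3)nn2)cc1)c1ccc(Br)cc1`, 44%
compound 2 `O=C(/C=C/c1ccc(OCc2cn(Cc3ccc(Br)cc3)nn2)cc1)c1ccc(Br)cc1`, 27%
compound 3 `O=C(/C=C/c1ccc(OCc2cn(Cc3cccc(F)c3)nn2)cc1)c1ccc(Br)cc1`, 37%

Compound 2 holds the lowest of the three numbers. Its nearest neighbour is compound 3, the step being a number 10 percentage points higher from compound 2 to compound 3 (within the scatter). The furthest is compound 1, and the step of a number 17 percentage points lower from compound 1 to compound 2 (beyond the scatter) is the only one of the three that goes beyond the scatter.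

Compound 4 `COc1ccc(C(=O)/C=C/c2ccc(OCc3cn(Cc4ccc(Br)cc4)nn3)cc2)cc1` is the next compound for this assay. It differs from compound 2 in one place: methoxy in place of bromo on an aromatic carbon, on the ring bound to the carbonyl, para to a large group.

Among the compounds with values here, no measured step touches this ring. Within the data shown here, the three steps change only the aryl on the saturated chain carbon bound to the triazole nitrogen, and the one step that swaps a ring substituent for another, a number 7 percentage points lower from compound 1 to compound 3 (within the scatter), stays within the scatter. The data therefore give no ground for a step beyond the scatter in this assay, in either direction, for compound 4; the expected step is a number 3 percentage points higher from compound 2 to compound 4 (within the scatter).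

For compound 4 the estimated value in this assay is 30%, expected to lie between 15% and 48%.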

Compound 4, percent growth inhibition at one concentration: 50%
The estimate for compound 4 lay 20 percentage points below the measured number; the measured number lies above the stated range.
By their numbers in this assay, from the lowest: compounds 2, 3, 1 and 4 (each within the scatter of the next, the first and the last beyond it).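

Within the data shown here, the ring bound to the carbonyl, which no earlier step had touched, proves able to move the number in this assay: methoxy in place of bromo on an aromatic carbon, para to a large group, gives a number 23 percentage points higher from compound 2 to compound 4 (beyond the scatter). Among these compounds, this step is modest and beyond the scatter, the same grade as the only earlier step of that kind, a number 17 percentage points lower from compound 1 to compound 2 (beyond the scatter), so changes at this position can count as much as changes on the aryl at the other end of the molecule. Nothing available bears on why the number moves with this exchange.

Among the compounds shown here, the change is seen only with the 4-bromophenyl group of compound 2 on the saturated chain carbon, so whether it would carry over to the 3-bromophenyl of compound 1 or the 3-fluorophenyl of compound 3 remains open. Also open, as far as these compounds go, is whether the step comes from gaining methoxy or losing bromo, a question that a plain hydrogen, a hydroxy group, an amine or a longer ethoxy chain at this position could begin to answer.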